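Swapping the aryl end of a thiosemicarbazone

This account rests on a few compounds, and the source may have more. Where it says the series, first, only, none or still open, it means among the compounds named here.

Within the data shown here, the three compounds measured so far share a core in which an isatin-derived piece is joined through a thiosemicarbazone linker to a second aryl group, and they differ in that aryl group and in the substituent on the core. Compound 1 `O=C1Nc2ccc(Br)cc2/C1=N/NC(=S)N/N=C/c1ccc(-c2ccccc2)cc1` carries a biphenyl end; in a functional assay on HeLa cells (Homo sapiens) for inhibition, read by MTT assay (a higher number here means a weaker inhibitor, a lower number a stronger inhibitor), compound 1 gives 3250 nM. Compound 2 `O=C1Nc2ccc(Br)cc2/C1=N/NC(=S)N/N=C/c1ccccc1Br` reaches only the limit of this assay, and for compound 2 that limit is > 50000 nM. Compound 3 `COc1ccc(/C=N/NC(=S)N/N=C2\C(=O)Nc3ccc(C)cc32)cc1O` carries a 3-hydroxy-4-methoxyphenyl end and a methyl on the core; in this assay compound 3 gives 2730 nM, the lowest of the two numbers, though its gap to compound 1 is within the scatter, so the two cannot be ranked. One value sits at the limit (the limit of > 50000 nM in this assay, at which 1 of the 3 values shown sits).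

Compound 4 `Cc1ccc2c(c1)/C(=N/NC(=S)N/N=C/c1c(F)cccc1Cl)C(=O)N2` keeps the core of compound 3 and changes only the aryl end: 2-chloro-6-fluorophenyl in place of 3-hydroxy-4-methoxyphenyl on a carbon with a double bond to nitrogen. Among the measured compounds shown here, no measured pair isolates such a change, so the expected step from compound 3 to compound 4 is a guess: a loss of potency of moderate size, a 3.3-fold higher number from compound 3 to compound 4 (0.52 log units; beyond the scatter), is expected. Compound 4 is therefore estimated at 9000 nM, between 2500 nM and 40000 nM.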

Compound 4, half-maximal inhibitory concentration: 1510 nM
The estimate for compound 4 lay 6.0-fold (0.78 log units) above the measured number; the whole stated range lies above it.
By their numbers in this assay, from the lowest: compounds 4, 3 and 1 (each within the scatter of the next, the first and the last beyond it). At a limit, above all of these: compound 2.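

Among these compounds, with the shared core held fixed, putting 2-chloro-6-fluorophenyl in place of 3-hydroxy-4-methoxyphenyl on a carbon with a double bond to nitrogen gives a 1.8-fold lower number from compound 3 to compound 4 (0.26 log units; within the scatter) in this assay, and this is the first step that changes one place alone. The two numbers cannot be told apart, so on this core the hydroxy and methoxy groups of compound 3 are not required for activity at this level: a ring with no hydrogen-bond donors or acceptors, carrying chlorine and fluorine instead, serves equally well in this cell assay. Nothing measured here accounts for why two such different aryl ends give indistinguishable numbers.

From the compounds shown here alone, it remains open whether chlorine or fluorine alone would give the same result, and whether the same swap would read the same way on the core of compound 1, which carries a bromine where compound 3 and compound 4 carry a methyl. Going by these compounds, it is also open how this position responds to an aryl end bearing an amine or a carboxylic acid, since a single step within the scatter says little about the range of groups allowed there.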